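A few compounds are considered here, and "the series" means these few. Any claim that something is new, unique, unknown or untested is made for them only; others in the source may bear on it.

In a functional assay on MCF7 cells (Homo sapiens) for antiproliferative activity, read by MTT assay, with a stated time of 48 h (on this read-out lower numbers stand for stronger inhibition and higher numbers for weaker inhibition), compound 1 `C=C(c1ccc2c(c1)C=CC(C)(C)O2)c1ccc(OC)cc1NC(=O)CO` gives 390 nM, while compound 2 `C=C(c1ccc2c(c1)C=CC(C)(C)O2)c1ccc(OC)cc1NC(=O)CNCC` gives 3370 nM, the higher of the two numbers and so the weaker inhibition. Compound 3 `C=C(c1ccc2c(c1)C=CC(C)(C)O2)c1ccc(OC)cc1NC(=O)CN(C)C` has not yet been measured. It differs from compound 2 in one place, on a saturated chain carbon bound to a carbonyl carbon, where dimethylamino stands in place of ethylamino: dimethylamino in place of ethylamino on a saturated chain carbon bound to a carbonyl carbon. The two groups hold the same atoms, joined differently. Among the compounds with values here, only one measured step bears on this, and only indirectly: an 8.6-fold higher number from compound 1 to compound 2 (0.94 log units; beyond the scatter), with ethylamino taking the place of hydroxy. That is a different swap from this one, so it sets no direction, and no step beyond the scatter is expected. The expected outcome is a 1.1-fold lower number from compound 2 to compound 3 (0.05 log units; within the scatter). The estimate for compound 3 is 3000 nM, with an expected range from 1000 nM to 9000 nM.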

Compound 3, half-maximal inhibitory concentration: 940 nM
Compound 3: the middle estimate sits 3.2-fold (0.50 log units) above what was measured; the measured number lies below the stated range.
By their numbers in this assay, from the lowest: compound 1; then compound 3; then compound 2.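

In this assay, the way the same atoms are joined matters on this saturated chain carbon bound to a carbonyl carbon: a 3.6-fold lower number from compound 2 to compound 3 (0.55 log units; beyond the scatter), although ethylamino and dimethylamino have the same heavy atoms and differ in the count only by the hydrogen-bond donor that ethylamino carries. So amines at this place are not interchangeable, yet dimethylamino does not bring the number down to that of the hydroxy compound, with a 2.4-fold higher number from compound 1 to compound 3 (0.38 log units; beyond the scatter). Nothing measured here explains why these groups differ.

Methylamino, diethylamino and a ring amine such as morpholine would show whether the trend seen with these two amines extends to other amines at this place. Methoxy in place of hydroxy would test whether the hydroxy group's hydrogen matters, and whether any group can go lower than hydroxy also remains open.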